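Methoxy on the benzyl end of a benzothiazole thioacetamide series

A few compounds are considered here, and "the series" means these few. Any claim that something is new, unique, unknown or untested is made for them only; others in the source may bear on it.

Measured so far:
compound 1, `COc1ccc(CNC(=O)CSc2nc3ccc(NC(C)=O)cc3s2)cc1`, 20500 nM
compound 2, `COc1ccc(CNC(=O)CSc2nc3ccc(NC(=O)c4ccccc4)cc3s2)cc1`, 21200 nM
compound 3, `COc1ccccc1C(=O)Nc1ccc2nc(SCC(=O)NCc3ccccc3)sc2c1`, 17200 nM

All three compounds share the same core and were tested in a functional assay on MCF7 cells (Homo sapiens) for cytotoxicity, read by MTT assay, with a stated time of 48 h; a higher number here means a weaker inhibitor, a lower number a stronger inhibitor. Going by the values given here, compound 1 gives 20500 nM and compound 2 gives 21200 nM; the one step between them, a 1.0-fold higher number from compound 1 to compound 2 (0.01 log units; within the scatter), lies within the scatter. Compound 3 gives 17200 nM, which is within the scatter of both compound 1 and compound 2, so on these numbers compound 3 sits level with the others rather than apart from them.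

Compound 4, `COc1ccc(CNC(=O)CSc2nc3ccc(NC(=O)c4ccccc4OC)cc3s2)cc1`, is compound 3 with one change: methoxy in place of hydrogen on an aromatic carbon. Among the compounds with values here, no measured pair isolates this change; the only measured step, from compound 1 to compound 2, alters the group on the carbonyl carbon at the other end of the molecule and is within the scatter. What the three numbers show is that the variations tried so far have moved nothing beyond the scatter. On that basis compound 4 is expected to stay close to compound 3, with a step of a 1.0-fold higher number from compound 3 to compound 4 (0.02 log units; within the scatter) that is not expected to exceed the scatter. The estimate for compound 4 in this assay is 18000 nM, with a range from 9000 nM to 36000 nM.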

Compound 4, half-maximal inhibitory concentration: 9300 nM
Beside the measured number, compound 4's estimate is 1.9-fold (0.29 log units) above it; measured number inside the range.
By their numbers in this assay, from the lowest: compounds 4, 3, 1 and 2 (each within the scatter of the next, the first and the last beyond it).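

In this assay, the step from benzyl to 4-methoxybenzyl, a 1.8-fold lower number from compound 3 to compound 4 (0.27 log units; within the scatter), does not separate the two compounds, so this methoxy has no effect that can be distinguished from the usual scatter. Going by these compounds alone, with the 4-methoxybenzyl end held fixed, the group on the carbonyl carbon does register for the first time: methoxy in place of hydrogen on the phenyl gives a 2.3-fold lower number from compound 2 to compound 4 (0.36 log units; beyond the scatter), and 2-methoxyphenyl in place of methyl gives a 2.2-fold lower number from compound 1 to compound 4 (0.34 log units; beyond the scatter), both modest, whereas plain phenyl in place of methyl gave a 1.0-fold higher number from compound 1 to compound 2 (0.01 log units; within the scatter). No supporting measurement is available to explain these steps.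

It remains open whether the 2-methoxyphenyl group would give a similar step with each benzyl end, since the compounds shown do not include the pair needed to test this. Going by these compounds, it is also open how a hydroxy group, an amine or a longer alkoxy chain would compare with methoxy on that phenyl ring, and whether any such group would move the number further than these modest steps.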